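From 3-chlorophenyl to 4-fluorophenyl on a saturated ring carbon

The compounds below may be only part of what the source reports. "The series", "measured", "known", "first", "only" and "open" are said of these compounds alone.

Results in a functional assay on OVCAR-8 cells (Homo sapiens) for antiproliferative activity, read by luminescence and CellTiter-Glo, with a stated time of 4 days; on this read-out lower numbers stand for stronger inhibition of growth and higher numbers for weaker inhibition of growth:
Compound 1 `COc1ccc(-c2nsc3c2NC(=O)CC3c2ccc3c(c2)OCCO3)cc1` gives 1410 nM
Compound 2 `COc1ccc(-c2nsc3c2NC(=O)CC3c2cccc(Cl)c2)cc1` gives 2920 nM
Compound 3 `COc1ccc(-c2nsc3c2NC(=O)CC3c2cccc(F)c2)cc1` gives 7540 nM

Compound 2 stands in the middle of these three numbers, second highest, with compound 1 giving a lower number and compound 3 a higher one. The next compound, compound 4 `COc1ccc(-c2nsc3c2NC(=O)CC3c2ccc(F)cc2)cc1`, has not yet been measured. It differs from compound 2 as follows: 4-fluorophenyl in place of 3-chlorophenyl on a saturated ring carbon. In words, 4-fluorophenyl stands in place of 3-chlorophenyl on a saturated ring carbon.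

Within the data shown here, the only measured step that bears on this change is a 2.6-fold higher number from compound 2 to compound 3 (0.41 log units; beyond the scatter), with fluoro in place of chloro on an aromatic carbon. That step is modest and lies beyond the scatter. The change to compound 4 also alters where the halogen stands on the ring, and no measurement here isolates that shift, so the expectation is loose. A step of similar modest size towards a higher number is expected in this assay. The expected step is a 2.1-fold higher number from compound 2 to compound 4 (0.31 log units; beyond the scatter), an estimate and not a measurement. For compound 4 the estimated value is 6000 nM, with an expected range from 2500 nM to 14000 nM.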

Compound 4, concentration for 50% growth inhibition: 4010 nM
Compound 4: the middle estimate sits 1.5-fold (0.18 log units) above what was measured; the range from low to high includes it.
By their numbers in this assay, from the lowest: compound 1; then compounds 2, 4 and 3 (each within the scatter of the next, the first and the last beyond it).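

In this assay, among these compounds, the new result gives the first reading at this saturated ring carbon of where a halogen stands on the phenyl ring: 4-fluorophenyl in place of 3-fluorophenyl reads as a 1.9-fold lower number from compound 3 to compound 4 (0.27 log units; within the scatter), so these two fluorophenyl groups cannot be told apart here. Set against 3-chlorophenyl, 4-fluorophenyl reads as a 1.4-fold higher number from compound 2 to compound 4 (0.14 log units; within the scatter), whereas 3-fluorophenyl reads as a 2.6-fold higher number from compound 2 to compound 3 (0.41 log units; beyond the scatter), so compound 4 lies within the scatter of both compound 2 and compound 3, although those two lie beyond the scatter of each other. Nothing given here accounts for these numbers.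

On these data alone, whether 4-chlorophenyl at this carbon would read like 3-chlorophenyl stays open, and so does the question of how a phenyl ring carrying an amine or a carboxylic acid would read in this assay. Also open is whether the small gaps among these halogenated phenyl groups hold in any cell line other than the one shown.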